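This account rests on a few compounds, and the source may have more. Where it says the series, first, only, none or still open, it means among the compounds named here.

Within the data shown here, in a physicochemical assay for lipophilicity (on this read-out higher numbers stand for higher lipophilicity and lower numbers for lower lipophilicity), three compounds on a shared core have numbers so far. Compound 1 `O=C1OCCN1c1cc(C(F)(F)F)ccc1[C@H]1CCOc2cc(S(=O)(=O)Nc3nccs3)ccc21` gives 2.1, compound 2 `O=S(=O)(Nc1nccs1)c1ccc2c(c1)OCC[C@@H]2c1ccc(C(F)(F)F)cc1-c1ccc(F)cc1` gives 4.5, and compound 3 `O=S(=O)(Nc1nccs1)c1ccc2c(c1)OCC[C@@H]2c1ccc(C(F)(F)F)cc1N1CCNCC1` gives 1.4, the lowest of the three. Compound 4 `O=C1COCCN1c1cc(C(F)(F)F)ccc1[C@H]1CCOc2cc(S(=O)(=O)Nc3nccs3)ccc21` has not yet been measured. It departs from compound 3 by 3-oxomorpholin-4-yl in place of piperazin-1-yl on an aromatic carbon, with 3-oxomorpholin-4-yl in place of piperazin-1-yl on an aromatic carbon, ortho to a large group and meta to a trifluoromethyl group.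

The most relevant measured step is the modest a number 0.70 log units lower from compound 1 to compound 3 (beyond the scatter), since the 2-oxo-1,3-oxazolidin-3-yl of compound 1 also carries a carbonyl in a non-aromatic ring. The large steps of a number 2.40 log units higher from compound 1 to compound 2 (beyond the scatter) and a number 3.10 log units lower from compound 2 to compound 3 (beyond the scatter) both involve 4-fluorophenyl, which compound 4 lacks, so they carry less weight here. Compound 4 is therefore expected to land near compound 1, reversing most of that modest step. The expected step is a number 0.60 log units higher from compound 3 to compound 4 (beyond the scatter), a modest rise. For compound 4 the estimated value is 2, with an expected range of 1.5 to 2.5.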

Compound 4, distribution coefficient: 1.8
Compound 4: the middle estimate sits 0.20 log units above what was measured; measured number inside the range.
By their numbers in this assay, from the lowest: compound 3; then compounds 4 and 1 (each within the scatter of the next); then compound 2.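

In this assay, 3-oxomorpholin-4-yl in place of piperazin-1-yl on this aromatic carbon, ortho to a large group and meta to a trifluoromethyl group, gives a number 0.40 log units higher from compound 3 to compound 4 (beyond the scatter) and also removes the hydrogen-bond donor of the ring. Set against 2-oxo-1,3-oxazolidin-3-yl, the same group gives a number 0.30 log units lower from compound 1 to compound 4 (within the scatter), so these two carbonyl-bearing rings cannot be told apart on this read-out, whereas 3-oxomorpholin-4-yl in place of 4-fluorophenyl gives a number 2.70 log units lower from compound 2 to compound 4 (beyond the scatter). Nothing among the measurements shown accounts for these steps.

The step from compound 3 swaps a ring nitrogen for oxygen and adds a carbonyl together, so the share of each stays unresolved. Morpholin-4-yl, with the ring oxygen but no carbonyl, or an open-chain amide at this position, could separate them, and how either would read remains open.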